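Working notes: aryl ether series, outlook for compound 4

This account rests on a few compounds, and the source may have more. Where it says the series, first, only, none or still open, it means among the compounds named here.

Compound 1 `Cc1ncc(OCCCCOc2ccc(C(=O)CC(C)(C)C)c(O)c2C)cc1C(=O)O` gives 79 nM in an assay for positive allosteric modulation of metabotropic glutamate receptor 3 (Rattus norvegicus) (a lower number here means that less compound is needed, a higher number that more compound is needed for the effect), the lowest number among the three measured compounds. Compound 2 `Cc1ccc(OCCCCOc2ccc(C(=O)CC(C)(C)C)c(O)c2C)cc1C(=O)O` gives 309 nM and compound 3 `COc1ccc(OCCCCOc2ccc(C(=O)CC(C)(C)C)c(O)c2C)cc1C(=O)O` gives 490 nM in this assay. Going by the values given here, the one step that swaps the ring carrying the carboxy group, a 3.9-fold higher number from compound 1 to compound 2 (0.59 log units; beyond the scatter), is a modest shift beyond the scatter; the further step a 1.6-fold higher number from compound 2 to compound 3 (0.20 log units; within the scatter) stays within the scatter, so the methoxy group on compound 3 leaves the number essentially unchanged against compound 2.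

Compound 4 `Cc1ccc(C(=O)O)cc1OCCCCOc1ccc(C(=O)CC(C)(C)C)c(O)c1C` differs from compound 1 in one place: 5-carboxy-2-methylphenyl in place of 5-carboxy-6-methylpyridin-3-yl on an oxygen on a saturated carbon. As in the step from compound 1 to compound 2, the ring with one hetero atom gives way to a ring of carbon only, while the carboxy group and the methyl group keep the same count but now stand as 5-carboxy-2-methylphenyl rather than 3-carboxy-4-methylphenyl. Among the compounds with values here, no measured pair covers this arrangement directly, so the step from compound 1 to compound 2 is the only guide. A modest rise of the number, roughly matching that step, is therefore expected for compound 4, a 3.8-fold higher number from compound 1 to compound 4 (0.58 log units; beyond the scatter), with wide uncertainty on both sides. The estimated value for compound 4 in this assay is 300 nM, within a range of 100 nM to 900 nM.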

Compound 4, half-maximal effective concentration: 892 nM
Beside the measured number, compound 4's estimate is 3.0-fold (0.47 log units) below it; measured number inside the range.
By their numbers in this assay, from the lowest: compound 1; then compounds 2, 3 and 4 (each within the scatter of the next, the first and the last beyond it).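

In this assay, the ring on an oxygen on a saturated carbon is sensitive to more than the loss of its hetero atom: the change to 5-carboxy-2-methylphenyl gives the larger shift (an 11-fold higher number from compound 1 to compound 4 (1.05 log units; beyond the scatter)), and compound 1 remains the lowest of the four compounds. Going by these compounds alone, the two carbon-only rings also separate from each other (a 2.9-fold higher number from compound 2 to compound 4 (0.46 log units; beyond the scatter)), so the arrangement of the carboxy and methyl groups on the ring alters the number even with no change in ring atoms, which the earlier steps could not show. There are no data at hand that account for either shift.

The compounds shown leave open how much of the larger shift belongs to the ring nitrogen and how much to the group arrangement, since a pyridine ring carrying the carboxy and methyl groups as in compound 4 does not appear among them. Going by these compounds, it also remains open whether a tetrazole in place of the carboxy group, or a chloro group in place of the methyl group, on the ring of compound 1 would keep a number close to that of compound 1.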